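Removing the phenyl from compound 1: an expected cytotoxicity step

The compounds below may be only part of what the source reports. "The series", "measured", "known", "first", "only" and "open" are said of these compounds alone.

Compound 1 (`CCCNNC(=O)c1ccc(-c2ccccc2)cc1`) gives 5900 nM in the test below
Compound 2 (`Cc1nc2ccccc2n1Cc1ccc(C(=O)NO)cc1`) gives 7900 nM in the same test

Both values come from an ADME assay on Huh-7 cells (Homo sapiens) for cytotoxicity, read by MTT assay, with a stated time of 3 days (on this read-out lower numbers stand for higher toxicity in this test and higher numbers for lower toxicity in this test), and lie within the usual scatter of each other, so compound 1 cannot be told apart from compound 2 on these numbers. Compound 3 (`CCCNNC(=O)c1ccccc1`) has not yet been measured. It differs from compound 1 in one place (hydrogen in place of phenyl on an aromatic carbon), with hydrogen in place of phenyl on an aromatic carbon. For the measured compounds named here, no measured pair shows what such a change does, so the expectation is a judgement with a wide margin. In this assay a step to a higher number, beyond the scatter, is expected. The estimated size of this change is a 6.8-fold higher number from compound 1 to compound 3 (0.83 log units; beyond the scatter) in this direction. For compound 3 the expected value is 40000 nM, with an estimated range from 12000 nM to 150000 nM.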

Compound 3, half-maximal cytotoxic concentration: 120000 nM
Estimate against measurement, compound 3: 3.0-fold (0.48 log units) below; measured number inside the range.
By their numbers in this assay, from the lowest: compounds 1 and 2 (each within the scatter of the next); then compound 3.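

In this assay, the phenyl on this aromatic carbon, para to a group of 7 heavy atoms, proves to matter: hydrogen in its place gives a 20-fold higher number from compound 1 to compound 3 (1.31 log units; beyond the scatter) and a large step. For the compounds shown here, compound 1 and compound 2 could not be told apart and differ in more than one place, so this pair is the first to tie a change in the read-out to a single position. Nothing available explains why the step is so large.

From the compounds shown here alone, it remains open whether any group at this position keeps the number low or whether the phenyl is special, which a methyl, a chlorine or a pyridyl ring in the same place would help to settle. One pair also cannot show whether the same exchange would have a similar effect on another core.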